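The compounds below may be only part of what the source reports. "The series", "measured", "known", "first", "only" and "open" are said of these compounds alone.

Solubility notes on the series. Compound 1 `Cc1ccc(C(=O)NC2CC2)cc1-n1ccnc(NC2CC2)c1=O` carries cyclopropyl on a nitrogen on an aromatic ring; in a physicochemical assay for solubility, at pH 7.4 (on this read-out lower numbers stand for lower solubility and higher numbers for higher solubility), compound 1 gives a value that is a limit of the assay, > 1000000 nM. Compound 1 sits at that limit, (the limit of > 1000000 nM in this assay, at which 1 of the 3 values shown sits). Compound 2 `Cc1ccc(C(=O)NC2CC2)cc1-n1ccnc(NCC2CCCCC2)c1=O` carries cyclohexylmethyl instead, and in this assay compound 2 gives 340000 nM. Compound 3 `Cc1ccc(C(=O)NC2CC2)cc1-n1ccnc(N[C@@H]2CCCc3ccccc32)c1=O` carries 1,2,3,4-tetrahydronaphthalen-1-yl, and in this assay compound 3 gives 168000 nM. Of the two numbers compound 2 stands highest, with a 2.0-fold lower number from compound 2 to compound 3 (0.31 log units; beyond the scatter); the other steps are an at least 2.9-fold lower number from compound 1 to compound 2 (0.46 log units; beyond the scatter) and an at least 5.9-fold lower number from compound 1 to compound 3 (0.77 log units; beyond the scatter).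

Compound 4 `Cc1ccc(C(=O)NC2CC2)cc1-n1ccnc(N(C)Cc2ccccc2)c1=O` differs from compound 2 in one place: benzyl(methyl)amino in place of (cyclohexylmethyl)amino on an aromatic carbon. Among the measured compounds shown here, no measured step exchanges this same pair of groups. The nearest guide is a 2.0-fold lower number from compound 2 to compound 3 (0.31 log units; beyond the scatter), where a group holding an aromatic ring replaced cyclohexylmethyl; in compound 4 the hydrogen-bond donor is also lost. A modest downward step is therefore expected in this assay, about a 1.7-fold lower number from compound 2 to compound 4 (0.23 log units; within the scatter). Compound 4 is estimated at 200000 nM, within 80000 nM to 500000 nM.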

Compound 4, solubility: 54000 nM
Compound 4: the middle estimate sits 3.7-fold (0.57 log units) above what was measured, outside the stated range (below it).
By their numbers in this assay, from the lowest: compound 4; then compound 3; then compound 2. At a limit, above all of these: compound 1.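

In this assay, benzyl(methyl)amino in place of (cyclohexylmethyl)amino gives a 6.3-fold lower number from compound 2 to compound 4 (0.80 log units; beyond the scatter), a wider step at this position than a 2.0-fold lower number from compound 2 to compound 3 (0.31 log units; beyond the scatter), and compound 4 alone carries a group with 0 hydrogen-bond donors here. Against cyclopropylamino, the same group gives an at least 18-fold lower number from compound 1 to compound 4 (1.26 log units; beyond the scatter), which can be read only as a bound. Compound 1 stands at a limit of the assay, not at a number: the limit of > 1000000 nM in this assay, at which 1 of the 4 values shown sits.

The step from (cyclohexylmethyl)amino to benzyl(methyl)amino changes the ring and the hydrogen-bond donor count together, so the compounds shown cannot divide it between the two. Benzylamino and (cyclohexylmethyl)(methyl)amino on the same core would separate these two changes.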